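A few compounds are considered here, and "the series" means these few. Any claim that something is new, unique, unknown or untested is made for them only; others in the source may bear on it.

In an ADME assay on L132 cells (Homo sapiens) for cytotoxicity, read by MTT assay, with a stated time of 72 h (on this read-out lower numbers stand for stronger inhibition and higher numbers for weaker inhibition), compound 1 `COc1ccc(C2=C(c3cc(OC)c(OC)c(OC)c3)C(=O)C(O)C2)cc1` gives < 1 ug/mL as a limit of the assay and not a number. Compound 2 `COc1ccc(C2=C(c3cc(OC)c(OC)c(OC)c3)C(=O)C(OC(C)=O)C2)cc1F` gives < 1 ug/mL as a limit too. Compound 2 thus stands at the limit of < 1 ug/mL in this assay, at which 2 of the 2 values shown sit, and cannot be ranked any more closely. The move to compound 3 `COc1ccc(C2=C(c3cc(OC)c(OC)c(OC)c3)C(=O)C(O)C2)cc1F` is acetoxy to hydroxy, with hydrogen in place of acetyl on an oxygen on a saturated carbon. Within the data shown here, no measured step shows what this change does in this assay so no shift beyond the usual scatter is expected. This expectation starts from compound 2 and its limit of < 1 ug/mL alone. The expected move is a step that the limit leaves unreadable from compound 2 to compound 3 and it may go unresolved if only a limit can be read again. For compound 3 the estimate is 0.5 ug/mL with an expected range from 0.15 ug/mL to 1.5 ug/mL in this measurement.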

Compound 3, half-maximal inhibitory concentration: < 1 ug/mL
Compound 3 gave a limit, no number; the forecaster's own chance of this, stated with the estimate: 65%; the middle value lies beyond the limit too.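

No step can be read among compound 1, compound 2 and compound 3, because they all stand at one limit: the limit of < 1 ug/mL in this assay, at which 3 of the 3 values shown sit.

The compounds shown leave open how far apart their true values lie, and whether changing acetoxy to hydroxy or hydrogen to fluoro has any effect.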